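This account rests on a few compounds, and the source may have more. Where it says the series, first, only, none or still open, it means among the compounds named here.

In a functional assay for inhibition, with Homo sapiens as the target (on this read-out lower numbers stand for an effect already at smaller amounts and higher numbers for an effect only at larger amounts of compound), compound 1 `Nc1ccc(C2=NNC(=O)CC2)cc1` gives 46.4 ug/mL. Among the measured compounds shown here, compound 2 `CCC(=O)Nc1ccc(C2=NNC(=O)CC2)cc1`, with propanoyl in place of hydrogen on a nitrogen on an aromatic ring, gives 0.64 ug/mL, the lower of the two numbers so far. The move between them is a 73-fold lower number from compound 1 to compound 2 (1.86 log units; beyond the scatter).

Compound 3 `CCCC(=O)Nc1ccc(C2=NNC(=O)CC2)cc1` has not yet been measured. Its structure departs from compound 2 by methyl in place of hydrogen on a saturated chain carbon, two bonds along the chain from a carbonyl carbon, which turns propanoyl into propylcarbonyl.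

For the measured compounds named here, only one measured step bears on this change, namely a 73-fold lower number from compound 1 to compound 2 (1.86 log units; beyond the scatter). That step put the whole propanoyl group onto the nitrogen, whereas the new change only extends a chain that is already there. Going by the values given here, no measured pair shows what lengthening this chain does, so the large size of that step does not carry over. The expectation is therefore for no shift beyond the scatter in either direction, and the expected move is a 1.1-fold higher number from compound 2 to compound 3 (0.04 log units; within the scatter). The estimated value for compound 3 is 0.7 ug/mL, with an expected range from 0.2 ug/mL to 2.5 ug/mL.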

Compound 3, half-maximal effective concentration: 1.44 ug/mL
The estimate for compound 3 lay 2.1-fold (0.31 log units) below the measured number; the range from low to high includes it.
By their numbers in this assay, from the lowest: compound 2; then compound 3; then compound 1.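

Compound 3 shows that the number in this assay responds to the length of this chain: methyl in place of hydrogen on a saturated chain carbon, two bonds along the chain from a carbonyl carbon, gives a 2.3-fold higher number from compound 2 to compound 3 (0.35 log units; beyond the scatter), a modest shift, yet one that lies beyond the scatter. Most of the large step seen with propanoyl remains after the extension, as propylcarbonyl in place of hydrogen on the nitrogen still gives a 32-fold lower number from compound 1 to compound 3 (1.51 log units; beyond the scatter), so a large step is now seen with two chain lengths rather than one. Nothing available explains why the longer chain gives the higher number.

With a single extension in hand, the compounds shown leave open whether a still longer chain would raise the number further, or whether the shorter acetyl group would lower it below that of compound 2. They also leave open how a branched chain, a phenyl ring or a terminal amine on this carbonyl would compare with propanoyl and propylcarbonyl.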